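A few compounds are considered here, and "the series" means these few. Any claim that something is new, unique, unknown or untested is made for them only; others in the source may bear on it.

Measured: compound 1 `O=C(O)c1ccc(-c2cnc(C(=O)CCCCCCc3ccccc3)o2)cc1`, 60 nM; compound 2 `Cc1ccc(-c2cnc(C(=O)CCCCCCc3ccccc3)o2)nc1`, 2.8 nM.

In an assay (Rattus norvegicus) for inhibition of Fatty-acid amide hydrolase 1 (Homo sapiens) (on this read-out higher numbers stand for weaker inhibition and lower numbers for stronger inhibition), compound 2 holds the lower of the two numbers; compound 1 sits higher, and the step of a 21-fold lower number from compound 1 to compound 2 (1.33 log units; beyond the scatter) was large. Compound 3 `NC(=O)c1cccc(-c2cnc(C(=O)CCCCCCc3ccccc3)o2)n1` is to be measured in this assay; it differs from compound 2 by 6-carbamoylpyridin-2-yl in place of 5-methylpyridin-2-yl on an aromatic carbon. For the measured compounds named here, only the step from compound 1 to compound 2 bears on this, and it exchanged the whole aryl group, whereas here the pyridyl ring is kept and only the group it carries changes from methyl to carbamoyl. A modest rise in the number is expected, a 2.1-fold higher number from compound 2 to compound 3 (0.33 log units; beyond the scatter), so compound 3 is estimated at 6 nM, range 1.5 nM to 25 nM.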

Compound 3, inhibition constant: 1 nM
Estimate against measurement, compound 3: 6.0-fold (0.78 log units) above; the measured number lies below the stated range.
By their numbers in this assay, from the lowest: compound 3; then compound 2; then compound 1.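

In this assay, 6-carbamoylpyridin-2-yl in place of 5-methylpyridin-2-yl gives a 2.8-fold lower number from compound 2 to compound 3 (0.45 log units; beyond the scatter), so this position tolerates a substituted pyridyl group with more heavy atoms, a hydrogen-bond donor and no loss of inhibition. Against the 4-carboxyphenyl group the change gives a 60-fold lower number from compound 1 to compound 3 (1.78 log units; beyond the scatter), and the 4-carboxyphenyl group stays at the highest number of the three. No measured evidence accounts for either step.

The compounds shown do not separate the effect of the carbamoyl group from that of its place on the pyridyl ring. Going by these compounds, how a carboxylic acid or an amine on that ring would read also remains open.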